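The compounds below may be only part of what the source reports. "The series", "measured", "known", "first", "only" and "open" are said of these compounds alone.

Series in a functional assay on SMMC-7721 cells (Homo sapiens) for antiproliferative activity, read by MTT assay, with a stated time of 72 h; a higher number here means a weaker inhibitor, a lower number a stronger inhibitor:
- Compound 1 `C#CCSc1nc(Sc2nnnn2CCN(C)C)c(C#N)c(-c2ccc(Cl)cc2)n1`: 7340 nM
- Compound 2 `C=CC(=O)Nc1ccccc1CN(C(=O)Nc1cccc(C(F)(F)F)c1)C1CCN(C(C)CCC)CC1`: 16200 nM
- Compound 3 `C#CCSc1nc(Sc2nccs2)c(C#N)c(-c2ccc(Cl)cc2)n1`: 6040 nM

Compound 1 lies within the scatter of compound 3, while compound 2 has the higher number, beyond the scatter. Compound 4 `C#CCSc1nc(Sc2nnnn2CCN(C)C)c(C#N)c(-c2cccc(Cl)c2)n1` carries 3-chlorophenyl in place of 4-chlorophenyl on an aromatic carbon, with the rest of compound 1 unchanged: 3-chlorophenyl in place of 4-chlorophenyl on an aromatic carbon. Among the compounds with values here, the data hold no measured step at this place. The nearest evidence is a 1.2-fold lower number from compound 1 to compound 3 (0.08 log units; within the scatter), a change on a sulfur, and it stays small. Taking compound 1 at 7340 nM as the anchor, no step beyond the scatter is expected in this assay. The expected step is a 1.0-fold lower number from compound 1 to compound 4 (0.02 log units; within the scatter). For compound 4 the estimate is 7000 nM, with an expected range of 3300 nM to 15000 nM.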

Compound 4, half-maximal inhibitory concentration: 8640 nM
The estimate for compound 4 lay 1.2-fold (0.09 log units) below the measured number; low and high end bracket the measured number.
By their numbers in this assay, from the lowest: compounds 3, 1, 4 and 2 (each within the scatter of the next, the first and the last beyond it).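

Moving the chlorine on the aryl group at this position, with 3-chlorophenyl replacing 4-chlorophenyl, gives a 1.2-fold higher number from compound 1 to compound 4 (0.07 log units; within the scatter) in this assay. Within the data shown here, this is the first step read at this aromatic carbon, and in this pair the place of the chlorine on the phenyl ring shifts the number by no more than the scatter. No measurement at hand explains this result. The compounds shown leave open how the position responds to a phenyl ring carrying a methoxy group or an amine instead of chlorine. As far as these compounds go, a phenyl ring without chlorine also remains open.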